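The source may hold more compounds than are shown below. What is called first, only, known or untested is meant among the compounds shown, and "the series" means these compounds.

Of the compounds shown here, three built on one shared core have been measured in a functional assay on A-431 cells (Homo sapiens) for inhibition, read by MTT assay, with a stated time of 72 h; on this read-out lower numbers stand for stronger inhibition and higher numbers for weaker inhibition. Compound 1 `COc1ccc(Nc2nc(Oc3cccc(NC(=O)C=C(C)C)c3)c3sccc3n2)cc1` gives 17600 nM, compound 2 `COc1ccc(Nc2nc(Oc3cccc(NC(=O)/C=C/C(C)C)c3)c3sccc3n2)cc1` gives 25200 nM, and compound 3 `COc1cccc(Nc2nc(Oc3cccc(NC(=O)/C=C/C(C)C)c3)c3sccc3n2)c1` gives 23400 nM. Compound 1 has the lowest of these three numbers, though all three lie within the usual scatter of one another. Compound 4 `COc1ccc(Nc2nc(Oc3cccc(NC(=O)C=C(C)C)c3)c3sccc3n2)cn1` has not yet been measured; it differs from compound 1 by 6-methoxypyridin-3-yl in place of 4-methoxyphenyl on a nitrogen on an aromatic ring. Within the data shown here, two measured steps bear on this change: the swap of the group on the carbonyl carbon, a 1.4-fold higher number from compound 1 to compound 2 (0.16 log units; within the scatter), and the swap of 3-methoxyphenyl for 4-methoxyphenyl on the aromatic amine nitrogen, a 1.1-fold lower number from compound 2 to compound 3 (0.03 log units; within the scatter). Both stayed within the scatter, so no step beyond the scatter is expected in this assay, the estimated step being no change at the digits printed from compound 1 to compound 4 (within the scatter). Compound 4 is therefore expected to give about 17600 nM, with a likely range from 7000 nM to 45000 nM.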

Compound 4, half-maximal inhibitory concentration: > 50000 nM
Compound 4 was reported as a limit; the forecaster's own chance of this, stated with the estimate: 5%; middle value at least 2.8-fold (0.45 log units) away from the limit.
By their numbers in this assay, from the lowest: compounds 1, 3 and 2 (each within the scatter of the next). At a limit, above all of these: compound 4.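

In this assay, compound 4 is reported only as a limit, > 50000 nM. Among these compounds, on the nitrogen on an aromatic ring, 6-methoxypyridin-3-yl in place of 4-methoxyphenyl gives an at least 2.8-fold higher number from compound 1 to compound 4 (0.45 log units; beyond the scatter), the first step beyond the scatter in this set. The earlier swap at this place, to 3-methoxyphenyl, gave a 1.1-fold lower number from compound 2 to compound 3 (0.03 log units; within the scatter), so moving the methoxy group left the number within the scatter, while this change of the ring did not.

Still open, as far as these compounds go, is how a plain phenyl or a 5-methoxypyridin-2-yl group would behave at this place. Also open, from the compounds shown here alone, is whether the same ring change would give a similar step with the 3-methylbut-1-en-1-yl amide of compound 2.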